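A few compounds are considered here, and "the series" means these few. Any claim that something is new, unique, unknown or untested is made for them only; others in the source may bear on it.

Measured so far in an assay on cells for displacement of a labelled ligand from Glucagon receptor (Homo sapiens), in the presence of a further agent that is not named here; a lower number here means a stronger inhibitor, a higher number a weaker inhibitor:
- compound 1, `CCCC(Oc1ccc(-n2cc(C(F)(F)F)c(C)n2)cc1)c1ccc(C(=O)NCCC(=O)O)cc1`: 1100 nM
- compound 2, `CCCC(Oc1ccc(-n2cccn2)cc1)c1ccc(C(=O)NCCC(=O)O)cc1`: 4100 nM

Compound 2 carries the highest of the two numbers in this assay, and its nearest neighbour is compound 1, which stands lower by a 3.7-fold higher number from compound 1 to compound 2 (0.57 log units; beyond the scatter) read in reverse. Within the data shown here, the one step that relates the two, a 3.7-fold higher number from compound 1 to compound 2 (0.57 log units; beyond the scatter), is modest and goes with loss of both groups on the five-membered ring.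

Compound 3, `CCCC(Oc1ccc(-n2cc(C)cn2)cc1)c1ccc(C(=O)NCCC(=O)O)cc1`, reverts part of that change: methyl in place of hydrogen on an aromatic carbon, so that the ring reads 4-methyl-1H-pyrazol-1-yl rather than 1H-pyrazol-1-yl. Among the measured compounds shown here, only the step from compound 1 to compound 2 bears on this, and it covers a larger change than a single methyl. A step in this assay smaller than that one, towards a lower number, is therefore expected for compound 3, as a 1.9-fold lower number from compound 2 to compound 3 (0.27 log units; within the scatter). The estimate for compound 3 in this assay is 2200 nM, with a range from 900 nM to 5000 nM.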

Compound 3, inhibition constant: 1900 nM
For compound 3 the middle estimate is 1.2-fold (0.06 log units) above the measured one; low and high end bracket the measured number.
By their numbers in this assay, from the lowest: compounds 1 and 3 (each within the scatter of the next); then compound 2.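

In this assay, a single methyl on the aromatic carbon two ring bonds from the ring nitrogen is enough for a step beyond the scatter (a 2.2-fold lower number from compound 2 to compound 3 (0.33 log units; beyond the scatter)), whereas the earlier step changed two groups at once. The remaining change, from 4-methyl-1H-pyrazol-1-yl to 3-methyl-4-(trifluoromethyl)-1H-pyrazol-1-yl, gives a step that stays within the scatter (a 1.7-fold higher number from compound 1 to compound 3 (0.24 log units; within the scatter)), so the series cannot separate compound 1 from compound 3 here. No measurement at hand accounts for either step.

From the compounds shown here alone, the separate contributions of the trifluoromethyl and of the second methyl in compound 1 remain open. Also open, going by these compounds, is how an ethyl, a chlorine or a nitrile on the same aromatic carbon would compare with the methyl of compound 3.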